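Cytotoxicity notes on the amide-substituted core series

A few compounds are considered here, and "the series" means these few. Any claim that something is new, unique, unknown or untested is made for them only; others in the source may bear on it.

Three compounds of this series have been run in an ADME assay on L6 cells (Rattus norvegicus) for cytotoxicity, read by fluorescence, with a stated time of 72 h; on this read-out lower numbers stand for stronger inhibition and higher numbers for weaker inhibition. Compound 1 `CN1CCN(C23CC(NC(=O)CN4CCCCC4)C(C(c4ccccc4)C2)C(c2ccccc2)C3)CC1` gives 22100 nM and stands highest of the three numbers, though its nearest neighbour, compound 3 `CN1CCN(C23CC(NCCC(=O)N4CCCC4)C(C(c4ccccc4)C2)C(c2ccccc2)C3)CC1` with 21500 nM, is almost indistinguishable from it, and its furthest, compound 2 `CN1CCN(C23CC(NC(=O)CCN4CCCCC4)C(C(c4ccccc4)C2)C(c2ccccc2)C3)CC1` with 15400 nM, is also within the scatter. All three sit in one narrow band: a 1.4-fold lower number from compound 1 to compound 2 (0.16 log units; within the scatter), a 1.0-fold lower number from compound 1 to compound 3 (0.01 log units; within the scatter), a 1.4-fold higher number from compound 2 to compound 3 (0.14 log units; within the scatter).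

Compound 4 `CCN(CC)CC(=O)NC1CC2(N3CCN(C)CC3)CC(c3ccccc3)C1C(c1ccccc1)C2` is the next candidate. It differs from compound 1 in a single place: diethylamino in place of piperidin-1-yl on a saturated chain carbon bound to a carbonyl carbon. Among the measured compounds shown here, none of the measured steps alters the amine on the chain carbon in this way; the closest analogue is the change from compound 1 to compound 2, where the amine was moved one carbon further out, and that step stayed within the scatter, as did every other step here. With the series so flat across the changes tried, a swap of one acyclic amine for a ring amine at the same place gives no reason to expect movement beyond the scatter in this assay.

Compound 4 is therefore expected near 21000 nM, between 9000 nM and 45000 nM, which means an expected step of a 1.1-fold lower number from compound 1 to compound 4 (0.02 log units; within the scatter).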

Compound 4, half-maximal inhibitory concentration: 26400 nM
Estimate against measurement, compound 4: 1.3-fold (0.10 log units) below, within the range that was stated.
By their numbers in this assay, from the lowest: compounds 2, 3, 1 and 4 (each within the scatter of the next).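

Working notes, diethylamino at the chain carbon

Among the compounds shown here, at the saturated chain carbon bound to a carbonyl carbon, this is the first change that replaces the six-membered non-aromatic ring of piperidin-1-yl with a group that has no ring, and in this assay it gives a 1.2-fold higher number from compound 1 to compound 4 (0.08 log units; within the scatter). The comparisons with the other two compounds read the same way, with a 1.2-fold higher number from compound 3 to compound 4 (0.09 log units; within the scatter) and a 1.7-fold higher number from compound 2 to compound 4 (0.23 log units; within the scatter), so among these four compounds neither the ring nor its replacement by diethylamino separates the numbers at this place. No supporting measurement bears on why the numbers stay together here.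

The compounds shown leave open whether an amine of another kind, such as a primary amine or morpholin-4-yl, would stay in the same band at this chain carbon, and whether a carboxylic acid there would do so. They also leave open whether a bulkier acyclic amine such as diisopropylamino, or a longer chain carrying diethylamino, would give a step beyond the scatter in this assay.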